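A few compounds are considered here, and "the series" means these few. Any claim that something is new, unique, unknown or untested is made for them only; others in the source may bear on it.

For the measured compounds named here, in an ADME assay for permeability, using PAMPA, at pH 7.4 (on this read-out higher numbers stand for higher permeability and lower numbers for lower permeability), compound 2 (`O=C(Nc1ccc(Cl)c(-c2nc3ccccc3s2)c1)c1cc([N+](=O)[O-])ccc1Cl`) gives 3 10^-6 cm/s and stands below compound 1 (`O=C(Nc1cccc(-c2nc3ccccc3s2)c1)c1cc([N+](=O)[O-])ccc1Cl`), which gives 12 10^-6 cm/s as the only other number so far. The change to compound 3 (`O=C(Nc1ccc(Cl)c(C(F)(F)F)c1)c1cc([N+](=O)[O-])ccc1Cl`) is trifluoromethyl in place of 1,3-benzothiazol-2-yl on an aromatic carbon. Going by the values given here, no measured step swaps these two groups. Among the compounds with values here, the sole step a 4.0-fold lower number from compound 1 to compound 2 (0.60 log units; beyond the scatter) came with chloro in place of hydrogen on an aromatic carbon, so it offers only a rough scale. A modest rise of similar size is expected, with a 2.7-fold higher number from compound 2 to compound 3 (0.43 log units; beyond the scatter) as the estimated step. Compound 3 is estimated at 8 10^-6 cm/s with 2.5 10^-6 cm/s to 25 10^-6 cm/s as the expected range.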

Compound 3, apparent permeability: 8 10^-6 cm/s
Compound 3: the middle estimate sits on the measured number at the digits printed, and the stated range covers the measured number.
By their numbers in this assay, from the lowest: compound 2; then compounds 3 and 1 (each within the scatter of the next).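

In this assay the position that carries 1,3-benzothiazol-2-yl in compound 2 proves sensitive to what sits on it: trifluoromethyl, a group with far fewer heavy atoms and no ring, gives a 2.7-fold higher number from compound 2 to compound 3 (0.43 log units; beyond the scatter) with the chloro group unchanged. For the compounds shown here, the earlier step concerned only the addition of chloro, so this is the first measured change at this position.

From the compounds shown here alone, whether a nitrile, a methoxy group or an amine here would shift the number the same way stays open, as does the size of this step without the chloro group. No measurement at hand explains the rise.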